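A few compounds are considered here, and "the series" means these few. Any claim that something is new, unique, unknown or untested is made for them only; others in the source may bear on it.

Compound 1 `CS(=O)(=O)c1ccc(-c2nc3ccccn3c2Sc2ccccc2)cc1` gives 70600 nM
Compound 2 `Cc1ccc(-c2nc3ccccn3c2Sc2ccccc2)cc1` gives 86700 nM

Going by the values given here, these values come from a functional assay on HeLa cells (Homo sapiens) for inhibition, read by MTT assay, with a stated time of 48 h (a lower number here means a stronger inhibitor, a higher number a weaker inhibitor), and lie within the scatter of each other, so compound 2 stands level with compound 1 on the only numbers available. Among the compounds with values here, the one measured step is a 1.2-fold higher number from compound 1 to compound 2 (0.09 log units; within the scatter) and it places methyl where methylsulfonyl stood on an aromatic carbon.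

Compound 3 `Cc1ccc(-c2nc3ccc(C)cn3c2Sc2ccccc2)cc1` differs from compound 2 by methyl in place of hydrogen on an aromatic carbon and this carbon lies on the six-membered aromatic ring with 1 nitrogen, two atoms from the ring nitrogen. Within the data shown here, no measured step touches that place, so a 1.2-fold higher number from compound 1 to compound 2 (0.09 log units; within the scatter) bears on the change only loosely, as the sole indication of how much a substituent swap has moved the numbers here. A step beyond the scatter is therefore not expected in this assay and the data favour no direction. For compound 3 the estimated value is 80000 nM with an expected range from 35000 nM to 160000 nM in this assay. The expected change is thus a 1.1-fold lower number from compound 2 to compound 3 (0.03 log units; within the scatter) and it remains an estimate until measured.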

Compound 3, half-maximal inhibitory concentration: 65200 nM
Compound 3: middle estimate off by 1.2-fold (0.09 log units), on the high side; the measured number falls inside the stated range.
By their numbers in this assay, from the lowest: compounds 3, 1 and 2 (each within the scatter of the next).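

Methyl in place of hydrogen on an aromatic carbon of the six-membered aromatic ring with 1 nitrogen, two atoms from the ring nitrogen, gives a 1.3-fold lower number from compound 2 to compound 3 (0.12 log units; within the scatter) in this assay, so this place on the shared core, untouched by the earlier step, accepts a methyl without a step beyond the scatter. With the earlier swap of methylsulfonyl for methyl, a 1.2-fold higher number from compound 1 to compound 2 (0.09 log units; within the scatter), two separate places have now been changed, and neither change has moved the number beyond the scatter. Nothing among the available data speaks to the reason for this result.

Going by these compounds, it remains open whether an amine, a carboxylic acid or a longer chain at this carbon, or a methyl on another carbon of the same ring, would produce a step beyond the scatter. It is also open whether any change to the shared core can move the number well away from the level of compound 2 at 86700 nM, since the steps shown so far span only a narrow part of what this assay can report.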